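Replacing the aminophenyl amide end of compound 3

The source may hold more compounds than are shown below. What is called first, only, known or untested is meant among the compounds shown, and "the series" means these compounds.

Compound 1 `CCOc1cc(NC(=O)CCCCCC(=O)Nc2cc(-c3ccccc3)ccc2N)cc2c1OCC([N+](=O)[O-])=C2` gives 28% in an assay on isolated protein for inhibition of protein deacetylase HDAC6 (Homo sapiens), read by fluorescence, with stated times of 10 min and 30 min, tested at 10 uM; a higher number here means more inhibition at the concentration tested (going by the name of the read-out), a lower number less inhibition.
Compound 2 `CCOc1cc(NC(=O)CCCCCCC(=O)Nc2ccccc2N)cc2c1OCC([N+](=O)[O-])=C2` gives 52%.
Compound 3 `CCOc1cc(NC(=O)CCCCCC(=O)Nc2ccccc2N)cc2c1OCC([N+](=O)[O-])=C2` gives 57%.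

Compound 3 stands highest of the three numbers in this assay: compound 2 lies within the scatter of it, as a number 5 percentage points higher from compound 2 to compound 3 (within the scatter) shows, whereas a number 29 percentage points higher from compound 1 to compound 3 (beyond the scatter) lies beyond the scatter. Compound 4 `CCOc1cc(NC(=O)CCCCCNC(=O)CCCc2ccccc2)cc2c1OCC([N+](=O)[O-])=C2` differs from compound 3 by ((3-phenylpropyl)carbonyl)amino in place of (2-aminophenyl)carbamoyl on a saturated chain carbon, five bonds along the chain from a carbonyl carbon. Neither measured step bears directly on this: the step from compound 1 to compound 3 alters a phenyl elsewhere, and the step from compound 2 to compound 3 alters chain length, while both keep the (2-aminophenyl)carbamoyl group that now leaves. All three measured compounds share that group, so the expectation is uncertain. Compound 4 is expected to give a lower number, a number 42 percentage points lower from compound 3 to compound 4 (beyond the scatter), with an estimate of 15% between -5% and 40%.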

Compound 4, a percentage reported as inhibition, at one concentration (the size of the read-out at that concentration, not a potency): 43%
For compound 4 the middle estimate is 28 percentage points below the measured one; the measured number lies above the stated range.
By their numbers in this assay, from the lowest: compound 1; then compounds 4, 2 and 3 (each within the scatter of the next, the first and the last beyond it).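

In this assay, among these compounds, the change to ((3-phenylpropyl)carbonyl)amino on this saturated chain carbon brings a number 14 percentage points lower from compound 3 to compound 4 (beyond the scatter) and no more, so inhibition survives the loss of the (2-aminophenyl)carbamoyl group that all the earlier compounds carried. Measured against the longer-chain compound 2, the new group gives a number 9 percentage points lower from compound 2 to compound 4 (within the scatter) and cannot be told apart from it. Nothing available explains why inhibition persists without that group.

On these data alone, whether the phenyl ring of the new group contributes remains open. So does how a simple acetylamino group or a carboxylic acid at this chain carbon would compare.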